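The source may report more compounds than this note shows. Statements on the series, on what has been measured and on what is new or still open speak of the compounds shown alone.

Compound 1 `O=C(Nc1ccc(Oc2ccnc3[nH]ccc23)c(F)c1)c1ccc(-c2ccccc2)cn1` is the strongest of the three measured compounds in a functional assay on PC-3 cells (Homo sapiens) for cytotoxicity, read by MTT assay, with a stated time of 72 h (a higher number here means a weaker inhibitor, a lower number a stronger inhibitor), where compound 1 gives 760 nM. Compound 2 `Cc1ccc(-c2ccc(C(=O)Nc3ccc(Oc4ccnc5[nH]ccc45)c(F)c3)nc2)cc1` carries a single change, (methyl in place of hydrogen on an aromatic carbon), and in this assay compound 2 gives 2640 nM; the step is a 3.5-fold higher number from compound 1 to compound 2 (0.54 log units; beyond the scatter). Compound 3 `Cc1ccc(-c2ccnc(C(=O)Nc3ccc(Oc4ccnc5[nH]ccc45)c(F)c3)c2)cc1` gives 3970 nM in this assay; the difference between its core and the core of compound 1 is not broken down here, and its value lies within the scatter of compound 2. Compound 4 `Cc1ccc(-c2ccnc(C(=O)Nc3ccc(Oc4ccnc5[nH]ccc45)c(F)c3)c2)c(C)c1` differs from compound 3 by methyl in place of hydrogen on an aromatic carbon. This is the same kind of change as that between compound 1 and compound 2, but not the same: here the methyl enters ortho to a large group and meta to a methyl group, whereas before it entered para to a large group. Because the earlier step was a 3.5-fold higher number from compound 1 to compound 2 (0.54 log units; beyond the scatter), compound 4 is expected to show a 1.8-fold higher number from compound 3 to compound 4 (0.25 log units; within the scatter). Compound 4 is thus estimated at 7000 nM, with a likely range from 2800 nM to 18000 nM.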

Compound 4, half-maximal inhibitory concentration: 4010 nM
Compound 4: middle estimate off by 1.7-fold (0.24 log units), on the high side; the measured number falls inside the stated range.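

In this assay the added methyl gives a 1.0-fold higher number from compound 3 to compound 4 (0.00 log units; within the scatter), so on this core the change cannot be told apart from the scatter. Carried from one core to the other, the change therefore does not keep its size: the same change on two cores in this assay, a 3.5-fold higher number (0.54 log units; beyond the scatter) from compound 1 to compound 2 and a 1.0-fold higher number (0.00 log units; within the scatter) from compound 3 to compound 4, 3.4-fold (0.54 log units) apart, beyond the scatter of two such steps. This shows that the step seen on the core of compound 1 cannot be transferred as it stands, but it rests on one pair per core, and because the methyl also enters at a different place in each pair, these compounds do not show whether the core or that place accounts for the gap.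

On these data alone, what an amine, a methoxy group or a chlorine atom would give in place of this methyl remains open on either core.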